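Extending the amine of compound 2 with a methylpiperidinyl group

A few compounds are considered here, and "the series" means these few. Any claim that something is new, unique, unknown or untested is made for them only; others in the source may bear on it.

Measured so far:
compound 1 `O=C1CN(c2nccc3[nH]c(-c4ccc(F)c(F)c4)nc23)CCN1` gives < 5000 nM in a physicochemical assay for solubility, read by HPLC, using the shake flask method, in phosphate buffer, with a stated time of 20 h, at pH 6.5 (on this read-out higher numbers stand for higher solubility and lower numbers for lower solubility), a value that is a limit of the assay rather than a number.
compound 2 `Fc1ccc(-c2nc3c(N4CCNCC4)nccc3[nH]2)cc1F` gives 150000 nM in this assay.

Compound 2 holds the only number shown in this assay; the other value shown is a limit (the limit of < 5000 nM in this assay, at which 1 of the 2 values shown sits). Among the compounds with values here, the single measured step, an at least 30-fold higher number from compound 1 to compound 2 (1.47 log units; beyond the scatter), placed piperazin-1-yl in place of 3-oxopiperazin-1-yl on an aromatic carbon, so it concerns a different part of the molecule than the change studied here.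

Compound 3 `CN1CCC(N2CCN(c3nccc4[nH]c(-c5ccc(F)c(F)c5)nc34)CC2)CC1` differs from compound 2 as follows: 1-methylpiperidin-4-yl in place of hydrogen on an amine nitrogen in a ring. Within the data shown here, no measured step touches the ring nitrogen in this way, so the measured step does not bear on it directly. In this assay the expectation for compound 3 is therefore a step of a 1.2-fold higher number from compound 2 to compound 3 (0.08 log units; within the scatter), within the scatter of the measurement. The estimated solubility of compound 3 is 180000 nM, with a range from 60000 nM to 500000 nM.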

Compound 3, solubility: 200000 nM
Beside the measured number, compound 3's estimate is 1.1-fold (0.05 log units) below it; low and high end bracket the measured number.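

Placing 1-methylpiperidin-4-yl in place of hydrogen on the amine nitrogen in the ring gave a 1.3-fold higher number from compound 2 to compound 3 (0.12 log units; within the scatter) in this assay, so this change leaves the read-out within the usual scatter. Within the data shown here, the earlier step concerned the 3-oxopiperazin-1-yl group, whereas this is the first reading for a change on the ring nitrogen itself, and it shows that the hydrogen there can give way to a group of 7 heavy atoms, itself a six-membered non-aromatic ring, without a step beyond the scatter. No measurement shown here bears on what lies behind this result.

With only 1-methylpiperidin-4-yl on this nitrogen, the compounds shown cannot say how far the result extends to other groups in that place, such as a simple methyl, an acetyl amide or a chain ending in a carboxylic acid. Among these compounds, they also leave open whether the methyl on the piperidine matters, since compound 3 has no counterpart with a hydrogen on that piperidine nitrogen, and whether a piperidin-3-yl group would read the same.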